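The compounds below may be only part of what the source reports. "The series", "measured", "known", "first", "only" and "open" are said of these compounds alone.

Working notes on the series. Compound 1 `CCC(=O)N(C)c1ccc2[nH]c(-c3n[nH]c4ccccc34)cc2n1` carries a propanoyl group on the ring nitrogen; in a functional assay on HCT-116 cells (Homo sapiens) for antiproliferative activity, read by MTT assay, with a stated time of 72 h (a lower number here means a stronger inhibitor, a higher number a weaker inhibitor), compound 1 gives 10800 nM. Compound 2 `CN(C(=O)c1ccc(Br)cc1)c1ccc2[nH]c(-c3n[nH]c4ccccc34)cc2n1` has a 4-bromophenyl on the carbonyl carbon instead, and in this assay compound 2 gives 6110 nM. Compound 3 `CN(c1ccc2[nH]c(-c3n[nH]c4ccccc34)cc2n1)S(=O)(=O)c1ccc(Cl)cc1` carries a (4-chlorophenyl)sulfonyl on that nitrogen, and in this assay compound 3 gives 5980 nM. That is the lowest of the three numbers, yet every step among them stays within the scatter: a 1.8-fold lower number from compound 1 to compound 2 (0.25 log units; within the scatter), a 1.8-fold lower number from compound 1 to compound 3 (0.26 log units; within the scatter), and a 1.0-fold lower number from compound 2 to compound 3 (0.01 log units; within the scatter). Compound 4 `CN(c1ccc2[nH]c(-c3n[nH]c4ccccc34)cc2n1)S(=O)(=O)c1ccc(Br)cc1` differs from compound 3 by bromo in place of chloro on an aromatic carbon. Among the compounds with values here, no measured step isolates this halogen swap; the nearest comparison is the last of the three steps, where a bromo aryl amide and a chloro aryl sulfonamide returned nearly the same number. Since all three steps are within the scatter, the step to compound 4 is expected to be none beyond the scatter, a 1.1-fold lower number from compound 3 to compound 4 (0.03 log units; within the scatter). Compound 4 is therefore expected to give about 5600 nM, within 2500 nM to 12500 nM.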

Compound 4, half-maximal inhibitory concentration: 9850 nM
Estimate against measurement, compound 4: 1.8-fold (0.25 log units) below; the range from low to high includes it.
By their numbers in this assay, from the lowest: compounds 3, 2, 4 and 1 (each within the scatter of the next).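

The halogen swap on the aromatic carbon para to a large group now has a direct reading: in this assay the step of a 1.6-fold higher number from compound 3 to compound 4 (0.22 log units; within the scatter) does not separate bromo from chloro on the sulfonyl aryl ring. Within the data shown here, with the 4-bromophenyl held constant, the exchange of carbonyl for sulfonyl can also be read for the first time, and the step of a 1.6-fold higher number from compound 2 to compound 4 (0.21 log units; within the scatter) does not resolve that change either. The step of a 1.1-fold lower number from compound 1 to compound 4 (0.04 log units; within the scatter) shows that (4-bromophenyl)sulfonyl and propanoyl on this nitrogen are not told apart, so every step among the four compounds remains within the scatter.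

Going by these compounds, whether an amine or a carboxylic acid in place of the halogen would move the number beyond the scatter stays open. No measurement at hand bears on the reason for these numbers.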